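A few compounds are considered here, and "the series" means these few. Any claim that something is new, unique, unknown or untested is made for them only; others in the source may bear on it.

Three compounds share one core and differ only in the group carried on the outer aromatic ring. Compound 1 `COc1cccc(OC)c1C(=O)Nc1nnc(-c2ccc(F)cc2)s1` gives 3.5 in a physicochemical assay for lipophilicity, measured as octanol-water partition (on this read-out lower numbers stand for lower lipophilicity and higher numbers for higher lipophilicity), compound 2 `COc1cccc(OC)c1C(=O)Nc1nnc(-c2ccc(Br)cc2)s1` gives 3.96, and compound 3 `COc1cccc(OC)c1C(=O)Nc1nnc(-c2ccc([N+](=O)[O-])cc2)s1` gives 2.54. Compound 3 thus stands lowest of the three: the step of a number 0.96 log units lower from compound 1 to compound 3 (beyond the scatter) and the step of a number 1.42 log units lower from compound 2 to compound 3 (beyond the scatter) both run downward, and the step of a number 0.46 log units higher from compound 1 to compound 2 (beyond the scatter) places compound 2 at the top.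

Compound 4 `CCOc1ccc(-c2nnc(NC(=O)c3c(OC)cccc3OC)s2)cc1` is not yet measured in this assay. The change from compound 3 to compound 4 is ethoxy in place of nitro on an aromatic carbon. The two steps that bear on it are those in which nitro entered in place of a halogen, one of them modest and one large, both downward. Removing nitro from compound 3 is therefore expected to send this assay upward, and the ethoxy that enters is expected to keep the value near the halogen compounds rather than further from them. The estimated step is a number 1.16 log units higher from compound 3 to compound 4 (beyond the scatter). For compound 4 the estimate in this assay is 3.7, with a range from 3.2 to 4.2.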

Compound 4, partition coefficient: 3.75
Beside the measured number, compound 4's estimate is 0.05 log units below it; the measured number falls inside the stated range.
By their numbers in this assay, from the lowest: compound 3; then compounds 1, 4 and 2 (each within the scatter of the next, the first and the last beyond it).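

At this position on the outer aromatic ring in this assay, ethoxy in place of nitro gives a number 1.21 log units higher from compound 3 to compound 4 (beyond the scatter), although the group leaving and the group entering each hold 3 heavy atoms. Against the halogens, ethoxy gives a number 0.21 log units lower from compound 2 to compound 4 (within the scatter) and a number 0.25 log units higher from compound 1 to compound 4 (within the scatter), so ethoxy is not separated from either halogen, even though those two stand apart with a number 0.46 log units higher from compound 1 to compound 2 (beyond the scatter), and nitro alone remains beyond the scatter of all three other groups. No supporting information is available to explain these differences.

From the compounds shown here alone, whether nitro stays alone at the low end with other groups at this position remains open, since an amine or a carboxylic acid could fall anywhere on this scale. Going by these compounds, whether a longer chain such as butoxy would stay with ethoxy is also open.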